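The source may report more compounds than this note shows. Statements on the series, on what has been measured and on what is new or still open speak of the compounds shown alone.

Measured so far in an ADME assay on a cell-free system (plasma, Rattus norvegicus) for protein binding:
- compound 1 `Nc1nccc(N2CC[C@H](NC(=O)Nc3ccc(Cl)c(C(F)(F)F)c3)C2)n1`, 99.4%
- compound 2 `CNc1nccc(N2CC[C@H](NC(=O)Nc3ccc(CN(C)C)c(C(F)(F)F)c3)C2)n1`, 91%
- compound 3 `O=C(Nc1ccc(Cl)c(C(F)(F)F)c1)N[C@H]1CCN(c2ccnc(NC3CC3)n2)C1`, 99.9%

Among these three, compound 2 has the highest unbound fraction: compound 1 stands nearest to it, and compound 3 furthest, both beyond the scatter. Among the measured compounds shown here, the only single-point step measured so far is a 6.0-fold lower unbound fraction from compound 1 to compound 3 (0.78 log units; beyond the scatter), a change on the other side of the shared core.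

Compound 4 `CCN1CCN(Cc2ccc(NC(=O)N[C@H]3CCN(c4ccnc(NC)n4)C3)cc2C(F)(F)F)CC1` differs from compound 2 in one place: 4-ethylpiperazin-1-yl in place of dimethylamino on a saturated chain carbon bound to an aromatic carbon. For the measured compounds named here, no measured step touches this position, so the step from compound 1 to compound 3 gives no direct guide, and the expectation rests on compound 2 alone. With the entering group being larger than the leaving one, a small shift toward more binding is expected, likely within the scatter, so the estimated step is a 1.3-fold lower unbound fraction from compound 2 to compound 4 (0.11 log units; within the scatter). Compound 4 is therefore expected to give about 93% in this assay, with a range from 84% to 97.5%.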

Compound 4, plasma protein binding: 84.2%
For compound 4 the middle estimate is 2.3-fold (0.35 log units) (unbound fraction) below the measured one, within the range that was stated.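

Among the compounds shown here, this is the first measured step at this position, on a saturated chain carbon bound to an aromatic carbon. In this assay, replacing dimethylamino, with 3 heavy atoms and no ring, by 4-ethylpiperazin-1-yl, with 8 heavy atoms and one six-membered non-aromatic ring, gives a 1.8-fold higher unbound fraction from compound 2 to compound 4 (0.24 log units; within the scatter), so this substantial change in the group leaves the read-out within the usual scatter. No measurement here bears on why the read-out stays within that scatter.

As far as these compounds go, the effect of a carboxylic acid or a morpholin-4-yl group at this same place remains open. Also open, from the compounds shown here alone, is whether the same exchange would stay within the scatter with a cyclopropylamino group in place of the methylamino group on the other side of the shared core.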